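Chain Length and Configuration in a Deacetylase Series

A few compounds are considered here, and "the series" means these few. Any claim that something is new, unique, unknown or untested is made for them only; others in the source may bear on it.

Compound 1, `Nc1ccccc1NC(=O)/C=C/c1cn([C@H]2C[C@H](C(=O)O)N(Cc3ccccc3)C2)nn1`, gives < 10% in an assay on cells for inhibition of histone deacetylase 11 (Homo sapiens), read by fluorescence, with stated times of 3 h and 30 min, tested at 2 uM, in the presence of a further agent that is not named here (a lower number here means less inhibition, a higher number more inhibition at the concentration tested (going by the name of the read-out)), a value that is a limit of the assay and not a number.
Compound 2, `Nc1ccccc1NC(=O)/C=C/c1cn([C@H]2C[C@H](C(=O)O)N(CCCc3ccccc3)C2)nn1`, gives < 10% in this assay, again a limit rather than a number.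
Compound 3, `Nc1ccccc1NC(=O)/C=C/c1cn([C@@H]2C[C@H](C(=O)O)N(Cc3ccccc3)C2)nn1`, gives < 10% in this assay, also a limit.

Between compound 1 and compound 2 the only change is phenethyl in place of phenyl on a saturated chain carbon bound to an amine nitrogen in a ring. The step that the two limits leave unreadable from compound 1 to compound 2 cannot be sized, because the limit of < 10% in this assay, at which 3 of the 3 values shown sit, leaves both ends of it unknown. Compound 1 and compound 3 share every atom and bond; their cores differ as the two compounds have the same atoms and bonds and differ only in configuration as drawn: 1 of 3 stereo elements differ; a stereocentre at a saturated ring carbon is drawn S in compound 1 and R in compound 3. The step that the two limits leave unreadable from compound 1 to compound 3 is equally unreadable, because the limit of < 10% in this assay, at which 3 of the 3 values shown sit, applies to both and the fact that compounds 1 and 3 differ only in the configuration as drawn adds no measured difference.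

Compound 4, `Nc1ccccc1NC(=O)/C=C/c1cn([C@@H]2C[C@H](C(=O)O)N(CCCc3ccccc3)C2)nn1`, is not yet measured. It relates to compound 3 as compound 2 relates to compound 1: the change is phenethyl in place of phenyl on a saturated chain carbon bound to an amine nitrogen in a ring, at the same place, so it is the same change.

Compound 4 is expected to sit at 4% in this assay, most likely again reported as a limit. The expected step that the limit leaves unreadable from compound 3 to compound 4 rests on a step that the two limits leave unreadable from compound 1 to compound 2, which gave no visible movement, and on (the limit of < 10% in this assay, at which 3 of the 3 values shown sit). The expected range for compound 4 runs from 0% to 14%.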

Compound 4, a percentage reported as inhibition, at one concentration (the size of the read-out at that concentration, not a potency): < 10%
Compound 4: only a limit was reported; the forecaster's own chance of this, stated with the estimate: 85%; the middle value is on the limit's open side.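

Compound 4 gives < 10% in this assay, which is a limit of the assay and not a number. Among these compounds, neither the change from compound 3 to compound 4 nor the one from compound 2 to compound 4 can be sized, because of a shared limit: the limit of < 10% in this assay, at which 4 of the 4 values shown sit. The four compounds leave open whether the chain on the ring nitrogen or the configuration at the saturated ring carbon affects inhibition at all.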